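The source may report more compounds than this note shows. Statements on the series, on what has been measured and on what is new or still open speak of the compounds shown alone.

Compound 1 `CC(=O)c1ccc(NC(=O)Cn2nc(-c3ccc(Cl)cc3)nc2N)cc1`: 15.4%
Compound 2 `C/C(=N/O)c1ccc(NC(=O)Cn2nc(C(F)(F)F)nc2N)cc1`: 20.5%

In a functional assay on OVCAR-8 cells (Homo sapiens) for inhibition, read by sulforhodamine B assay, with a stated time of 48 h, tested at 10 uM (a lower number here means less inhibition of growth, a higher number more inhibition of growth at the concentration tested), compound 2 gives 20.5% and compound 1 gives 15.4%. These two values lie within the usual scatter, so they cannot be ranked. Compound 3 `CC(=O)c1ccc(NC(=O)Cn2nc(C(F)(F)F)nc2N)cc1` changes compound 2 in one place: a group of 3 heavy atoms (2 carbon, 1 oxygen; no ring) in place of a group of 4 heavy atoms (2 carbon, 1 nitrogen, 1 oxygen; no ring), on an aromatic carbon. An acetyl stands on an aromatic carbon, para to a large group. Going by the values given here, no measured pair isolates this change, so no shift beyond the scatter is expected. Compound 1, which also carries acetyl, gives 15.4%. The estimated change is a number 3.5 percentage points lower from compound 2 to compound 3 (within the scatter). For compound 3 the expected value is 17%, within an estimated range of 5% to 32%.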

Compound 3, percent growth inhibition at one concentration: 13.3%
Estimate against measurement, compound 3: 3.7 percentage points above; the range from low to high includes it.
By their numbers in this assay, from the lowest: compounds 3, 1 and 2 (each within the scatter of the next).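

In this assay, acetyl in place of the group with the nitrogen and oxygen gives a number 7.2 percentage points lower from compound 2 to compound 3 (within the scatter), so these two groups on the aromatic carbon cannot be told apart here. With acetyl held fixed, trifluoromethyl in place of 4-chlorophenyl gives a number 2.1 percentage points lower from compound 1 to compound 3 (within the scatter), so this much larger exchange of groups also shows no readable difference. Nothing measured here offers a reason for either result. Still open, from the compounds shown here alone, is whether an amine or a carboxylic acid in place of acetyl would shift growth inhibition beyond the usual scatter.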